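A few compounds are considered here, and "the series" means these few. Any claim that something is new, unique, unknown or untested is made for them only; others in the source may bear on it.

Working notes on the series.

Three compounds share a core and differ in the aryl group carried on the exocyclic carbon. Compound 1 is `COc1cccc(/C=C2\CCC/C(=C\c3ccccc3Cl)C2=O)c1OC` and in a functional assay on HT-1080 cells (Homo sapiens) for cytotoxicity, read by MTT assay, with a stated time of 72 h (on this read-out lower numbers stand for stronger inhibition and higher numbers for weaker inhibition), compound 1 gives 11700 nM. Compound 2, `COc1cccc(/C=C2\CCC/C(=C\c3cccc(Cl)c3)C2=O)c1OC`, differs from compound 1 by 3-chlorophenyl in place of 2-chlorophenyl on a double-bonded chain carbon bound to a double-bonded ring carbon; in this assay compound 2 gives 10300 nM. The step is a 1.1-fold lower number from compound 1 to compound 2 (0.06 log units; within the scatter), so the two values are not distinguished by this read-out.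

Compound 3 is `COc1ccc(/C=C2\CCC/C(=C\c3ccccc3Cl)C2=O)cc1OC`; in this assay compound 3 gives 6800 nM. The difference between the core of compound 3 and the core of compound 1 is not broken down here. The values of compound 3 and compound 2, and of compound 3 and compound 1, lie within the usual scatter of each other, so no ordering among the three is claimed.

Compound 4, `COc1ccc(/C=C2\CCC/C(=C\c3cccc(Cl)c3)C2=O)cc1OC`, is not yet measured. It differs from compound 3 by 3-chlorophenyl in place of 2-chlorophenyl on a double-bonded chain carbon bound to a double-bonded ring carbon, the same change, at the same place, as that from compound 1 to compound 2. The expectation for compound 4 therefore rests on compound 3 and on the one earlier occurrence of the change; because a 1.1-fold lower number from compound 1 to compound 2 (0.06 log units; within the scatter) was within the scatter, the step from compound 3 to compound 4 is expected to be small, at about a 1.1-fold lower number from compound 3 to compound 4 (0.04 log units; within the scatter). Compound 4 is estimated at 6200 nM in this assay, with a range from 3000 nM to 12500 nM reflecting that this rests on a single prior step.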

Compound 4, half-maximal inhibitory concentration: 4900 nM
Beside the measured number, compound 4's estimate is 1.3-fold (0.10 log units) above it; low and high end bracket the measured number.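

In this assay the change from 2-chlorophenyl to 3-chlorophenyl on a double-bonded chain carbon bound to a double-bonded ring carbon gives a 1.4-fold lower number from compound 3 to compound 4 (0.14 log units; within the scatter) and so does not separate the two compounds on this read-out. Set beside its earlier occurrence on the other core, the step does not differ from it: the same change on two cores in this assay, a 1.1-fold lower number (0.06 log units; within the scatter) from compound 1 to compound 2 and a 1.4-fold lower number (0.14 log units; within the scatter) from compound 3 to compound 4, 1.2-fold (0.09 log units) apart, within the scatter of two such steps. The change can therefore be carried between these two cores with no detectable difference in its outcome, but this does not show that it has a real effect on either core, nor that it would behave the same way on any core beyond these two.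

The compounds shown leave open whether any replacement of the chlorophenyl group gives a step beyond the scatter in this assay, for instance a phenyl ring carrying a carboxylic acid or an amine, or a longer chain in place of the aryl group. They also leave open whether the two steps seen here would look the same on any other cell line or read-out, since all four compounds are shown in this one assay only.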